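The compounds below may be only part of what the source reports. "The series", "measured", "known", "first", "only" and "open" are said of these compounds alone.

Measured so far in an assay on HEK293 cells for agonist activity at transient receptor potential cation channel subfamily M member 8 (Homo sapiens), read by fluorescence and calcium flux, with a stated time of 15 min; a higher number here means that more compound is needed for the effect, a lower number that less compound is needed: compound 1 `CCN(Cc1ccsc1)C(=O)COc1ccc(C)cc1` gives 88 nM; compound 2 `CCN(Cc1ccccn1)C(=O)COc1ccc(C)cc1` gives 16000 nM; compound 3 `CCN(C(=O)COc1ccc(C)cc1)C(C)c1cccs1` is recorded as "not active" (no number reported), with no number.

Compound 3 therefore has no place on the numerical scale: it sits outside the measured range, and the two numbered compounds, 1 and 2, only bracket where the branched analogue might have fallen had a value been obtained. Among the compounds with values here, the one step in the set, a 180-fold higher number from compound 1 to compound 2 (2.26 log units; beyond the scatter), is large and runs toward a higher number, the only quantitative guide to swapping one five-membered or six-membered heteroaryl for another on this nitrogen.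

The next compound, compound 4 `CCN(Cc1cc[nH]n1)C(=O)COc1ccc(C)cc1`, differs from compound 3 as follows: (1H-pyrazol-3-yl)methyl in place of 1-(thiophen-2-yl)ethyl on an amide-type nitrogen. Within the data shown here, no step is recorded for this pair, and the change touches two things at once, the branching on the chain carbon and the aromatic ring. Compound 4 returns to the unbranched methylene arrangement of compounds 1 and 2 while carrying a nitrogen-containing ring, as compound 2 does. On that basis compound 4 is expected to register a number in this assay, but a high one, nearer compound 2 than compound 1. The estimate for compound 4 in this assay is 8000 nM, with a range from 1500 nM to 40000 nM; a result reported only as a limit remains a real possibility.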

Compound 4, half-maximal effective concentration: "not active" (no number reported)
Nothing numeric was reported for compound 4; no gap can be computed for the estimate.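

Compound 3 and compound 4 both carry no number in this assay, so no step can be read between them, nor from compound 4 to compound 1 or compound 2. The compounds shown leave open how (1H-pyrazol-3-yl)methyl compares numerically with the other groups on this amide-type nitrogen. No supporting data bear on this result.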